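Ethoxy in place of 8-aminooctyl on the amide nitrogen

The compounds below may be only part of what the source reports. "The series", "measured", "known", "first", "only" and "open" are said of these compounds alone.

Measured so far:
compound 1 `CCCCCCCCCCCNC(=O)[C@H]1OC(n2cnc3c(N)ncnc32)[C@H](O)[C@@H]1O` gives 123 nM
compound 2 `CCC(C)NC(=O)[C@H]1OC(n2cnc3c(N)ncnc32)[C@H](O)[C@@H]1O` gives 198 nM
compound 3 `NCCCCCCCCNC(=O)[C@H]1OC(n2cnc3c(N)ncnc32)[C@H](O)[C@@H]1O` gives 29 nM

These three compounds share a core and differ only in the group on the amide-type nitrogen. In an assay on cell membranes for binding affinity to 2-oxoglutarate receptor 1 (Rattus norvegicus), read by radioligand binding (a higher number here means a weaker inhibitor, a lower number a stronger inhibitor), compound 3 stands lowest of the three numbers: the step of a 4.2-fold lower number from compound 1 to compound 3 (0.63 log units; beyond the scatter) and the step of a 6.8-fold lower number from compound 2 to compound 3 (0.83 log units; beyond the scatter) are both beyond the scatter, so compound 3 is the strongest binder among the measured compounds.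

Compound 4 `CCONC(=O)[C@H]1OC(n2cnc3c(N)ncnc32)[C@H](O)[C@@H]1O` has not yet been measured in this assay. It differs from compound 3 by ethoxy in place of 8-aminooctyl on an amide-type nitrogen. Both measured steps bear on this change, since each of them arrives at the 8-aminooctyl group from a group without the amino: the undecyl of compound 1 and the sec-butyl of compound 2. Compound 4 moves away from that group again, to a short ethoxy, so the expected direction is a higher number. The sec-butyl of compound 2 is the nearer comparison in size, and compound 2 gives 198 nM.

Compound 4 is therefore expected to give about 300 nM, within a range of 100 nM to 1500 nM, which corresponds to an expected step of a 10-fold higher number from compound 3 to compound 4 (1.01 log units; beyond the scatter).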

Compound 4, inhibition constant: 67 nM
Compound 4: the middle estimate sits 4.5-fold (0.65 log units) above what was measured, outside the stated range (below it).
By their numbers in this assay, from the lowest: compound 3; then compounds 4, 1 and 2 (each within the scatter of the next, the first and the last beyond it).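

In this assay, a short ethoxy on the amide-type nitrogen, with no amino group, gives only a 2.3-fold higher number from compound 3 to compound 4 (0.36 log units; beyond the scatter) and so loses far less than a move away from the 8-aminooctyl group had seemed to imply, though compound 3 remains the strongest binder of the four. Ethoxy in place of sec-butyl gives a 3.0-fold lower number from compound 2 to compound 4 (0.47 log units; beyond the scatter) and shows that, among the short groups, the choice of group at this nitrogen matters even without an amino group, so a long amino-bearing chain is not the only route to a lower number. Nothing in the data accounts for either step.

The compounds shown leave open whether the oxygen of the ethoxy group contributes, a question that a plain ethyl or propyl group on the same nitrogen would help to settle. They also leave open how the number depends on chain length and on the end group, which a shorter 2-aminoethyl chain or an octyl chain ending in a carboxylic acid could test.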